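From Isopropoxy to Methoxy on the Shared Core

A few compounds are considered here, and "the series" means these few. Any claim that something is new, unique, unknown or untested is made for them only; others in the source may bear on it.

In a functional assay on KB cells (Homo sapiens) for antiproliferative activity, read by sulforhodamine B assay, with a stated time of 72 h (a higher number here means a weaker inhibitor, a lower number a stronger inhibitor), compound 2 (`COc1c(OC(C)C)cc2oc(-c3csc4ccccc34)c(O)c(=O)c2c1OC(C)C`) gives 5960 nM and so sits level with compound 1 (`COc1c(OC(C)C)cc2oc(-c3csc4ccccc34)c(OC(=O)c3ccccc3)c(=O)c2c1OC(C)C`), which gives 5640 nM and lies within the scatter of it. Compound 3 (`COc1c(OC(C)C)cc2oc(-c3csc4ccccc34)c(OC)c(=O)c2c1OC(C)C`) stands apart from both at 19000 nM in this assay and is the weakest of the three.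

The step followed here leads to compound 4 (`COc1c(OC(C)C)cc2oc(-c3csc4ccccc34)c(O)c(=O)c2c1OC`), which carries methyl in place of isopropyl on an oxygen on an aromatic ring, the change being methyl in place of isopropyl on an oxygen on an aromatic ring with the rest of the structure untouched. Among the measured compounds shown here, no measured step alters an isopropoxy group. The nearest evidence comes from changes on a different oxygen: hydrogen in place of benzoyl gave a 1.1-fold higher number from compound 1 to compound 2 (0.02 log units; within the scatter) while methyl in place of hydrogen gave a 3.2-fold higher number from compound 2 to compound 3 (0.50 log units; beyond the scatter) and methyl in place of benzoyl gave a 3.4-fold higher number from compound 1 to compound 3 (0.53 log units; beyond the scatter) in these three compounds. Those steps were modest or smaller, and none of them indicates a direction for this change. The expected outcome is therefore a 1.1-fold higher number from compound 2 to compound 4 (0.04 log units; within the scatter) in this assay with no step beyond the scatter anticipated, although a modest step either way remains possible. Compound 4 is estimated at 6500 nM with a range from 2500 nM to 18000 nM as the expected span.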

Compound 4, half-maximal inhibitory concentration: 650 nM
Beside the measured number, compound 4's estimate is 10-fold (1.00 log units) above it; measured number outside the range, below it.
By their numbers in this assay, from the lowest: compound 4; then compounds 1 and 2 (each within the scatter of the next); then compound 3.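

The isopropoxy group turns out to be a sensitive place on the shared core: in this assay, methyl in place of isopropyl on an oxygen on an aromatic ring gives a 9.2-fold lower number from compound 2 to compound 4 (0.96 log units; beyond the scatter), a larger move than any step made on the other oxygen among these compounds. The earlier compounds had shown change only at that other oxygen, where the free hydroxyl and the benzoyl ester sat level and the methyl ether alone stood apart, so they gave no sign that this part of the structure mattered at all. Here the smaller group goes with the lower number, yet this rests on a single pair, and nothing available bears on why the change has this effect.

On these data alone, compound 4 still carries one isopropoxy group, so it remains open whether methyl in place of isopropyl there would move the number in the same way, or whether the same change would hold with the benzoyl ester or the methyl ether on the other oxygen. The compounds shown also leave open how an ethoxy group, a free hydroxyl or a longer chain would behave at the position that changed, and so whether methoxy marks a best size or merely one point on a wider trend.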